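Swapping one aryl group while watching cell tolerance

A few compounds are considered here, and "the series" means these few. Any claim that something is new, unique, unknown or untested is made for them only; others in the source may bear on it.

Two compounds in this set share a common core and differ only in one aryl group. Compound 1 `Cc1cc(-c2cc(Cl)cc(Cl)c2)cc(C)c1Nc1ccnc(Nc2ccc(C#N)cc2)n1` carries a 3,5-dichlorophenyl group; in an ADME assay on MT4 cells (Homo sapiens) for cytotoxicity, read by MTT assay, with a stated time of 4 days (a higher number here means that more compound is tolerated, a lower number that less compound is tolerated), compound 1 gives 4290 nM. Compound 2 `Cc1cc(-c2c(C)cccc2C)cc(C)c1Nc1ccnc(Nc2ccc(C#N)cc2)n1` carries a 2,6-dimethylphenyl group in its place, and in this assay compound 2 gives 2590 nM. The step of a 1.7-fold lower number from compound 1 to compound 2 (0.22 log units; within the scatter) is within the scatter, so the two compounds cannot be told apart on tolerance. Compound 2 has the lowest of the two numbers, with compound 1 nearest at a gap that the scatter covers.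

Compound 3 `Cc1cc(-c2ccccc2Cl)cc(C)c1Nc1ccnc(Nc2ccc(C#N)cc2)n1` is not yet measured. It differs from compound 2 as follows: 2-chlorophenyl in place of 2,6-dimethylphenyl on an aromatic carbon. Within the data shown here, the only measured step that bears on this, from compound 1 to compound 2, also changed this same aryl group and stayed within the scatter. That gives no reason to expect a step beyond the scatter in this assay for compound 3. Compound 3 is therefore expected at 3000 nM, with a range from 1200 nM to 8000 nM, an estimated step of a 1.2-fold higher number from compound 2 to compound 3 (0.06 log units; within the scatter).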

Compound 3, half-maximal cytotoxic concentration: 3990 nM
Beside the measured number, compound 3's estimate is 1.3-fold (0.12 log units) below it; the range from low to high includes it.
By their numbers in this assay, from the lowest: compounds 2, 3 and 1 (each within the scatter of the next).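

With 2-chlorophenyl at this position, this assay shows a 1.5-fold higher number from compound 2 to compound 3 (0.19 log units; within the scatter) when it takes the place of 2,6-dimethylphenyl, and a 1.1-fold lower number from compound 1 to compound 3 (0.03 log units; within the scatter) when it takes the place of 3,5-dichlorophenyl, so both new steps stay within the scatter. Among these compounds, the earlier pair compared only two aryl groups, each with two substituents, while this result adds a ring with a single chlorine, and all three compounds still cannot be told apart on tolerance, even though the group on this aromatic carbon, para to a large group and meta to two methyl groups, has now differed in the kind, number and placing of its substituents. Nothing available here explains why these changes leave the numbers so close, and the data give no cause for it.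

The compounds shown carry only chlorine or methyl on this ring, so it stays open whether an amine, a carboxylic acid or a longer chain there would give a step beyond the scatter. It also stays open whether the unsubstituted phenyl group would fall among these three compounds or apart from them.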